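Replacing Pyridin-2-yl with 4-Chlorophenyl on a Shared Core

The source may report more compounds than this note shows. Statements on the series, on what has been measured and on what is new or still open speak of the compounds shown alone.

Of the compounds shown here, two that share a core have been measured in an assay on CHO cells for displacement of a labelled ligand from adenosine receptor A1 (Homo sapiens), read by scintillation counting, tested at 10 uM; a higher number here means more inhibition at the concentration tested (going by the name of the read-out), a lower number less inhibition. Compound 1 `Cc1csc(N)c1C(=O)c1ccc(Cl)cc1` carries a methyl group on the core and gives 1%. Compound 2 `CC(C)(C)Cc1c(-c2ccccn2)sc(N)c1C(=O)c1ccc(Cl)cc1`, which carries a neopentyl group and a pyridin-2-yl group instead, gives 1% in this assay. Compound 2 therefore stands level with compound 1 at the digits shown, and the two values lie within the scatter of each other, so no difference between them can be read from these numbers.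

Compound 3 `CC(C)(C)Cc1c(-c2ccc(Cl)cc2)sc(N)c1C(=O)c1ccc(Cl)cc1` has not yet been measured in this assay. It differs from compound 2 in one place: 4-chlorophenyl in place of pyridin-2-yl on an aromatic carbon. For the measured compounds named here, since both compound 1 and compound 2 show almost no inhibition, and no measured step moves the read-out beyond the scatter, the step from compound 2 to compound 3 is expected to be small, a number 2 percentage points higher from compound 2 to compound 3 (within the scatter), with no direction beyond the scatter. Compound 3 is therefore estimated to give about 3% in this assay, within a range from -8% to 18%.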

Compound 3, a percentage reported as inhibition, at one concentration (the size of the read-out at that concentration, not a potency): 1%
Compound 3: the middle estimate sits 2 percentage points above what was measured; low and high end bracket the measured number.
By their numbers in this assay, from the lowest: compounds 1, 2 and 3 (each within the scatter of the next).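

In this assay, putting 4-chlorophenyl in place of pyridin-2-yl on this aromatic carbon, next to the ring sulfur, gives no change at the digits printed from compound 2 to compound 3 (within the scatter). For the compounds shown here, this is the first comparison that changes a single place, and it shows that the read-out stays flat when a six-membered aromatic ring with a ring nitrogen and one hydrogen-bond acceptor gives way to a carbon-only ring with a chlorine and no acceptor. The result has limited reach, however, as it comes from compounds with almost no inhibition at the concentration tested, and no data here explain it.

From the compounds shown here alone, whether an amine or a carboxylic acid at this position, or a longer chain in place of the neopentyl group, would move the read-out beyond the usual scatter remains open. The three compounds also lie too close together to show whether any change to the shared core can raise inhibition in this assay, so the importance of this position for binding to the receptor cannot yet be judged.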